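This account rests on a few compounds, and the source may have more. Where it says the series, first, only, none or still open, it means among the compounds named here.

The measured compounds, with their values in an ADME assay on microsomes from liver (Mus musculus) for metabolic stability, read by LC-MS, with a stated time of 10 min, tested at 0.5 uM; a higher number here means that more of the compound is left, a lower number that less of the compound is left:

compound 1, `c1ccc2c(c1)CN[C@@H](CN(CC[C@H]1CCCNC1)[C@H]1CCCc3cccnc31)C2`, gives 56%
compound 2, `c1cnc(CN(CCCN2CCNCC2)[C@H]2CCCc3cccnc32)nc1`, gives 78%
compound 3, `CC(C)N1CCN(CCCN(C[C@H]2Cc3ccccc3CN2)[C@H]2CCCc3cccnc32)CC1`, gives 58%

Compound 3 stands second highest of the three numbers in this assay. Its nearest neighbour is compound 1, which sits within the scatter of it, while compound 2 lies beyond the scatter above it.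

The step from compound 3 to compound 4 changes the chain end: piperazin-1-yl in place of (4-isopropylpiperazin-1-yl)methyl on a saturated chain carbon, two bonds along the chain from an amine nitrogen. Compound 4 is `c1ccc2c(c1)CN[C@@H](CN(CCN1CCNCC1)[C@H]1CCCc3cccnc31)C2`.

Within the data shown here, only one measured step is related to this change, a number 2 percentage points higher from compound 1 to compound 3 (within the scatter), where the same position carries a different ring; that step was within the scatter. Among the measured compounds shown here, compound 2, which carries an unsubstituted piperazin-1-yl on a longer chain and a different core, shows a higher value than compound 3, but no step between those two is known, and the difference could come from the core as much as from the chain. Compound 4 is therefore expected to give a number near that of compound 3, with a number 6 percentage points higher from compound 3 to compound 4 (within the scatter) as the expected step, most likely within the scatter. The estimate for compound 4 in this assay is 64%, within 50% to 80%.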

Compound 4, percent of the compound remaining: 79%
Compound 4: middle estimate off by 15 percentage points, on the low side; measured number inside the range.
By their numbers in this assay, from the lowest: compounds 1 and 3 (each within the scatter of the next); then compounds 2 and 4 (each within the scatter of the next).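

In this assay, the place on a saturated chain carbon, two bonds along the chain from an amine nitrogen, had shown no measurable response so far, since the only earlier step there was a number 2 percentage points higher from compound 1 to compound 3 (within the scatter). Compound 4 shows that the place does respond: piperazin-1-yl in place of (4-isopropylpiperazin-1-yl)methyl gives a number 21 percentage points higher from compound 3 to compound 4 (beyond the scatter), and piperazin-1-yl in place of piperidin-3-yl gives a number 23 percentage points higher from compound 1 to compound 4 (beyond the scatter), so the same group stands clear of two different predecessors on the shared core. The compounds shown offer no measurement that explains this rise.

The change from compound 3 to compound 4 removes the isopropyl group and also shortens what hangs from the chain, so these compounds leave open which of the two differences carries the step. A (piperazin-1-yl)methyl group or a 4-isopropylpiperazin-1-yl group at this place would separate them, and a 4-methylpiperazin-1-yl group would show whether a smaller substituent on that ring nitrogen keeps the higher number.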